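Compound 2 to compound 4: cyclopropyl to propyl

The source may report more compounds than this note shows. Statements on the series, on what has been measured and on what is new or still open speak of the compounds shown alone.

Measured in a physicochemical assay for solubility, in phosphate buffer, at pH 6.8; on this read-out lower numbers stand for lower solubility and higher numbers for higher solubility
- compound 1 `CCn1c(NC(C)C)nc2c(C3CCNCC3)csc2c1=O` gives 1100 ug/mL
- compound 2 `CCn1c(NC2CC2)nc2ccsc2c1=O` gives 430 ug/mL
- compound 3 `CCn1c(NC(C)C)nc2c(C3CCN(C(=O)c4ccccc4)C3)csc2c1=O` gives 21 ug/mL

Compound 2 holds the middle place of the three, under compound 1 and over compound 3, and both gaps lie beyond the usual scatter. Compound 4 `CCCNc1nc2ccsc2c(=O)n1CC` has no value yet in this assay and differs from compound 2 by propyl in place of cyclopropyl on a nitrogen on an aromatic ring. Within the data shown here, no measured pair carries this change, so the three values offer no direct guide to it. The expected step (a 1.3-fold lower number from compound 2 to compound 4 (0.13 log units; within the scatter)) is none beyond the scatter. For compound 4 the estimated value is 320 ug/mL (expected range 130 ug/mL to 750 ug/mL).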

Compound 4, solubility: 69 ug/mL
The estimate for compound 4 lay 4.6-fold (0.67 log units) above the measured number; the whole stated range lies above it.
By their numbers in this assay, from the lowest: compound 3; then compound 4; then compound 2; then compound 1.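

In this assay, among these compounds, the first measured pair at this position gives a 6.2-fold lower number from compound 2 to compound 4 (0.79 log units; beyond the scatter), so this change is not neutral on the core of compound 2. Both groups hold 3 heavy atoms, all carbon, and the one listed structural difference is the loss of the three-membered ring. No available measurement accounts for the step.

Going by these compounds, it remains open whether butyl, or a propyl chain ending in an amine, on this nitrogen would read closer to compound 2 or compound 4. On these data alone, it also remains open whether the same step recurs on the core of compound 1.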